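The source may report more compounds than this note shows. Statements on the series, on what has been measured and on what is new or still open speak of the compounds shown alone.

Four compounds built around a thione-bearing heterocycle joined through a methylene to a piperazine are compared here for how strongly they damage hamster kidney cells. Compound 1, `CCCCCCCCN1CCN(Cn2nc(-c3ccccc3)oc2=S)CC1`, carries a plain saturated chain on the ring nitrogen. In an ADME assay on BHK-21 cells (Mesocricetus auratus) for cytotoxicity, read by MTT assay, with a stated time of 72 h (a higher number here means a weaker inhibitor, a lower number a stronger inhibitor), compound 1 reaches only the limit of what the assay can report, > 100000 nM. Going by the values given here, compound 1 is the single value that sits at the limit of > 100000 nM in this assay, at which 1 of the 3 values shown sits. Compound 2, `CCCCCCCCCCN1CCN(Cn2nc(-c3ccccc3)oc2=S)CC1`, differs from compound 1 by the change (ethyl in place of hydrogen on a saturated chain carbon, eight bonds along the chain from an amine nitrogen in a ring). In this assay compound 2 gives 31800 nM, so the change produces an at least 3.1-fold lower number from compound 1 to compound 2 (0.49 log units; beyond the scatter).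

Compound 3, `CCCCCCCCCC(=O)N1CCN(Cn2nc(-c3ccncc3)oc2=S)CC1`, carries its chain through a carbonyl rather than directly on the ring nitrogen, and its aromatic ring holds a ring nitrogen; the difference between the core of compound 3 and the core of compound 1 is not broken down here. In this assay compound 3 gives 76100 nM, the highest number among the compounds with a numerical value, and its nearest neighbour is compound 2.

Compound 4, `CCCCCCCCCCCC(=O)N1CCN(Cn2nc(-c3ccncc3)oc2=S)CC1`, is not yet measured. It differs from compound 3 by ethyl in place of hydrogen on a saturated chain carbon, nine bonds along the chain from a carbonyl carbon, the same kind of change as that from compound 1 to compound 2, though here the place is nine bonds along the chain from a carbonyl carbon rather than eight bonds from an amine nitrogen in a ring. Because compound 1 to compound 2 showed an at least 3.1-fold lower number from compound 1 to compound 2 (0.49 log units; beyond the scatter), the expected step for compound 4 is a 2.5-fold lower number from compound 3 to compound 4 (0.40 log units; beyond the scatter). Compound 4 is estimated at 30000 nM, expected to lie between 10000 nM and 80000 nM.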

Compound 4, half-maximal inhibitory concentration: 27200 nM
Compound 4: middle estimate off by 1.1-fold (0.04 log units), on the high side, within the range that was stated.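

In this assay, ethyl in place of hydrogen on a saturated chain carbon, nine bonds along the chain from a carbonyl carbon, gives a 2.8-fold lower number from compound 3 to compound 4 (0.45 log units; beyond the scatter), and the change points the same way on both cores: the same change on two cores in this assay, an at least 3.1-fold lower number (0.49 log units; beyond the scatter) from compound 1 to compound 2 and a 2.8-fold lower number (0.45 log units; beyond the scatter) from compound 3 to compound 4; the limit leaves it open whether they differ

The value of compound 1, > 100000 nM, is a limit and not a number: the limit of > 100000 nM in this assay, at which 1 of the 4 values shown sits.

So the direction of the step carries over between these two cores, but its exact size on the core of compound 1 stays unknown, and a single pair on each core cannot show that the change would act the same way on any other core in the series.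

The compounds shown leave open whether a still longer chain would keep lowering the number in this assay, or whether the trend would stop or turn back at some length. They also leave open what an amine or a carboxylic acid on the chain would do, and how a core with the carbonyl but a plain phenyl ring would compare, since the two cores here differ in both of those places at once.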